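This account rests on a few compounds, and the source may have more. Where it says the series, first, only, none or still open, it means among the compounds named here.

Working notes on the series. In an assay on isolated protein for inhibition of DNA topoisomerase 1 (Homo sapiens), with a stated time of 15 min, tested at 200 uM (on this read-out higher numbers stand for more inhibition at the one concentration tested (going by the name of the read-out) and lower numbers for less inhibition), compound 1 `COc1c(N2CC[C@@H](CO)C2)c(F)cc2c(=O)c(C(=O)O)cn(Cc3ccc(-c4ccccc4)cc3)c12` gives 10% and compound 3 `COc1c(N2CC[C@@H](CN)C2)c(F)cc2c(=O)c(C(=O)O)cn(Cc3ccc(-n4cccn4)cc3)c12` gives 10%; these two values lie within the scatter of each other, so no order between them is claimed. Compound 2 `COc1c(F)c(F)cc2c(=O)c(C(=O)O)cn(Cc3ccc(-c4ccccc4)cc3)c12` is reported in this assay only as "not active" (no number reported), with no single number behind it, so compound 2 stands nowhere on the numerical scale of the series; it has no figure to set beside compound 1 or compound 3.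

Compound 4 `CNCCNc1c(F)cc2c(=O)c(C(=O)O)cn(Cc3ccc(-c4ccccc4)cc3)c2c1OC` is not yet measured. It differs from compound 2 in one place: (2-(methylamino)ethyl)amino in place of fluoro on an aromatic carbon

Going by the values given here, no step between two measured compounds is on record for this change. Since compound 1 and compound 3, both carrying a nitrogen-containing substituent at the carbon that bears fluoro in compound 2, give only low inhibition, any step from compound 2 to compound 4 in this assay is expected to be small, upward if at all, and likely not beyond the usual scatter. Compound 4 is therefore estimated at 10% in this assay, with an expected range from 0% to 25%.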

Compound 4, a percentage reported as inhibition, at one concentration (the size of the read-out at that concentration, not a potency): 10%
Compound 4: middle estimate and measured number agree at the digits printed, and the stated range covers the measured number.
By their numbers in this assay, from the lowest: compounds 1, 3 and 4 (each within the scatter of the next).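

In this assay, (2-(methylamino)ethyl)amino in place of 3-(hydroxymethyl)pyrrolidin-1-yl on this aromatic carbon gives no change at the digits printed from compound 1 to compound 4 (within the scatter), so a chain with no ring reads the same here as a substituent with a ring. Compound 4 gives 10%, whereas compound 2, with fluoro at this carbon, is reported only as "not active", so the size of that change cannot be read. Nothing on record explains these readings.

Open, going by these compounds, is whether a piperazin-1-yl group or a longer chain ending in a dimethylamino group at this aromatic carbon would read any differently in this assay. Also open is whether any substituent here can move the reading beyond the scatter of these compounds.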